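The source may report more compounds than this note shows. Statements on the series, on what has been measured and on what is new or still open speak of the compounds shown alone.

Measured so far:
- Compound 1, `O=C(Nc1cccc2cn[nH]c12)N1CCN(Cc2cccc(Oc3ccc(Cl)cc3)c2)CC1`: 1300 nM
- Compound 2, `Cc1nc2cc(NC(=O)N3CCN(Cc4cccc(Oc5ccc(Cl)cc5)c4)CC3)ccc2o1`: 7.7 nM
- Compound 3, `O=C(Nc1noc2ccccc12)N1CCN(Cc2cccc(Oc3ccc(Cl)cc3)c2)CC1`: 10 nM

All three share the same core and differ only in the ring system attached to the amide-type nitrogen. In an assay on isolated protein for inhibition of Fatty-acid amide hydrolase 1 (Homo sapiens), with a stated time of 60 min (a higher number here means a weaker inhibitor, a lower number a stronger inhibitor), compound 3 stands second highest of the three numbers; its nearest neighbour is compound 2, at a 1.3-fold higher number from compound 2 to compound 3 (0.11 log units; within the scatter), while compound 1 lies far off, at a 130-fold lower number from compound 1 to compound 3 (2.11 log units; beyond the scatter).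

Compound 4, `O=C(Nc1noc2cnccc12)N1CCN(Cc2cccc(Oc3ccc(Cl)cc3)c2)CC1`, has not yet been measured. It differs from compound 3 in one place: a group of 9 heavy atoms (6 carbon, 2 nitrogen, 1 oxygen; one five-membered aromatic ring with 2 hetero atoms, one six-membered aromatic ring with 1 hetero atom) in place of a group of 9 heavy atoms (7 carbon, 1 nitrogen, 1 oxygen; one five-membered aromatic ring with 2 hetero atoms, one six-membered aromatic ring of carbon only), on an amide-type nitrogen. For the measured compounds named here, none of the measured steps makes exactly this exchange. The step from compound 1 to compound 3 shows that swapping one such bicyclic group for another can move this assay a long way, whereas the step from compound 2 to compound 3 shows that a smaller alteration of the same region stays within the scatter. The change to compound 4 keeps both rings aromatic and the same atom count, so a small step is expected, a 1.5-fold higher number from compound 3 to compound 4 (0.18 log units; within the scatter), with compound 4 estimated at 15 nM, within 5 nM to 50 nM.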

Compound 4, half-maximal inhibitory concentration: 0.5 nM
Estimate against measurement, compound 4: 30-fold (1.48 log units) above; measured number outside the range, below it.
By their numbers in this assay, from the lowest: compound 4; then compounds 2 and 3 (each within the scatter of the next); then compound 1.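

In this assay, exchanging the carbon-only six-membered aromatic ring for one with 1 hetero atom gives a 20-fold lower number from compound 3 to compound 4 (1.30 log units; beyond the scatter) while the heavy-atom count stays the same and both rings stay aromatic. This shows that the group on the amide-type nitrogen can respond strongly to a change inside the ring, not only to a swap of one whole bicyclic group for another. The same group also gives a 15-fold lower number from compound 2 to compound 4 (1.19 log units; beyond the scatter) and a 2600-fold lower number from compound 1 to compound 4 (3.41 log units; beyond the scatter) and so makes compound 4 the strongest inhibitor of the four.

Going by these compounds, how a fluorine atom or a methoxy group on that six-membered ring would change the number remains open, as does the effect of placing the ring nitrogen elsewhere. Nothing shown here explains the gain.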